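Fluoro added to the aryl ether ring of compound 1

The source may report more compounds than this note shows. Statements on the series, on what has been measured and on what is new or still open speak of the compounds shown alone.

In an ADME assay on MT2 cells (Homo sapiens) for cytotoxicity, read by MTT assay (a higher number here means that more compound is tolerated, a lower number that less compound is tolerated), compound 1 (`N#Cc1cc2c(Oc3ccccc3OCCn3ccc(=O)[nH]c3=O)cc(F)cn2c1`) gives 40000 nM. Its closest companion, compound 2 (`N#Cc1cc2c(Oc3ccccc3OCCn3ccc(=O)[nH]c3=O)cccc2[nH]1`), gives 72000 nM in this assay, and the two values sit within the usual scatter of each other, so neither can be placed above or below the other. Compound 3 (`N#Cc1cc2c(Oc3ccccc3OCCn3ccc(=O)[nH]c3=O)cc(Cl)cc2o1`) sits at the limit of > 100000 nM in this assay, at which 1 of the 3 values shown sits, and in this assay compound 3 gives > 100000 nM, which is a limit of the assay rather than a number.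

Compound 4 (`N#Cc1cc2c(Oc3ccc(F)cc3OCCn3ccc(=O)[nH]c3=O)cc(F)cn2c1`) differs from compound 1 in a single place: fluoro in place of hydrogen on an aromatic carbon. Within the data shown here, no measured pair in this set shares such a change, so there is no measured step to lean on. Across the three compounds shown, this assay gives numbers that lie close together or at its limit, so the step from compound 1 to compound 4 is expected to stay within the scatter, no change at the digits printed from compound 1 to compound 4 (within the scatter). For compound 4 the estimate in this assay is 40000 nM, with a range from 15000 nM to 100000 nM.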

Compound 4, half-maximal cytotoxic concentration: 50000 nM
Beside the measured number, compound 4's estimate is 1.3-fold (0.10 log units) below it; the measured number falls inside the stated range.
By their numbers in this assay, from the lowest: compounds 1, 4 and 2 (each within the scatter of the next). At a limit, above all of these: compound 3.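

In this assay, fluoro in place of hydrogen on an aromatic carbon, meta to a large group and para to a large group, gives a 1.3-fold higher number from compound 1 to compound 4 (0.10 log units; within the scatter). Among these compounds, this is the first step in the set that changes a single place, since the earlier compounds differ from one another in more than one place and offered no such comparison. It shows that this position on the aryl ether ring takes a fluoro with no change that can be told from the scatter, and nothing shown gives a cause for this result.

Going by these compounds, whether a methoxy, an amine or a carboxylic acid at the same place would move the number beyond the scatter remains open. Also open, on these data alone, is whether the same fluoro step would hold on the cores of compound 2 and compound 3.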